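Amide variation on a dimethoxy tetralin acetamide core

The compounds below may be only part of what the source reports. "The series", "measured", "known", "first", "only" and "open" are said of these compounds alone.

Measured compounds:
Compound 1, `COc1cc2c(cc1OC)C(CC(=O)NC(C)(C)C)CC2`, with 33.3% in a functional assay on the whole organism (strain Wistar) for inhibition, with Rattus norvegicus as the target, read by paw edema, with stated times of 60 min and 3 h, at a dose of 100 mg/kg by the oral route; on this read-out higher numbers stand for more inhibition at the one dose given (going by the name of the read-out) and lower numbers for less inhibition.
Compound 2, `COc1cc2c(cc1OC)C(CC(=O)N1CCCCC1)CC2`, with 31.9% in this assay.

Among the compounds with values here, compound 2 has the lower of the two numbers so far, but its nearest neighbour, compound 1, lies a number 1.4 percentage points lower from compound 1 to compound 2 (within the scatter), so the two cannot be placed in any order. Compound 3, `COc1cc2c(cc1OC)C(CC(=O)NCCO)CC2`, has not yet been measured. It differs from compound 2 by (2-hydroxyethyl)amino in place of piperidin-1-yl on a carbonyl carbon.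

Within the data shown here, only one measured step touches the same place: the change on the carbonyl carbon a number 1.4 percentage points lower from compound 1 to compound 2 (within the scatter), which left the read-out unchanged within the scatter. Among the measured compounds shown here, both compound 1 and compound 2 carry a bulky group there, whereas compound 3 carries a short chain bearing donors; this is a different kind of change, so the one step is only a weak guide. On the evidence available, no step beyond the scatter is expected for compound 3 in this assay, and its estimated change is a number 0.9 percentage points lower from compound 2 to compound 3 (within the scatter). Compound 3 is therefore expected to give 31% in this assay, with a range from 17% to 45%.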

Compound 3, a percentage reported as inhibition, in the whole organism at one dose (the size of the read-out at that dose, not a potency): 12.3%
For compound 3 the middle estimate is 18.7 percentage points above the measured one; measured number below the stated range.
By their numbers in this assay, from the lowest: compound 3; then compounds 2 and 1 (each within the scatter of the next).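

Within the data shown here, the group on the carbonyl carbon is not indifferent in this assay, as the one earlier step had left open: (2-hydroxyethyl)amino in place of piperidin-1-yl gives a number 19.6 percentage points lower from compound 2 to compound 3 (beyond the scatter). The same holds against the other earlier amide, where 2-hydroxyethyl in place of tert-butyl on an amide-type nitrogen gives a number 21 percentage points lower from compound 1 to compound 3 (beyond the scatter). Because compound 1 and compound 3 both keep the amide hydrogen, that hydrogen alone does not separate them, and the difference in that pair lies in the group on the nitrogen; tert-butyl and piperidin-1-yl, by contrast, could not be told apart. Nothing available bears on why the number falls with this change.

The compounds shown leave open whether the lower number follows the hydroxyl itself or the unbranched two-carbon chain that carries it, and an ethyl or a 2-methoxyethyl group on the amide nitrogen would separate the two. They also leave open how a longer chain ending in hydroxyl, or a morpholin-4-yl group on the carbonyl carbon, would read in this assay.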